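Swapping a small aromatic group on the sulfonyl sulfur

The source may report more compounds than this note shows. Statements on the series, on what has been measured and on what is new or still open speak of the compounds shown alone.

The three measured compounds and their readings:

Compound 1, `CC1CCN(C2CCN(S(=O)(=O)c3cccnc3)CC2)CC1`, gives 2400 nM.
Compound 2, `CC1CCN(C2CCN(S(=O)(=O)c3ccc(OCc4ccccc4)cc3)CC2)CC1`, gives 385 nM.
Compound 3, `CC1CCN(C2CCN(S(=O)(=O)c3ccccc3-c3ccc(Cl)cc3)CC2)CC1`, gives 202 nM.

All three share a common core and differ only in the group attached to the sulfonyl sulfur. In a functional assay on DLD-1 cells (Homo sapiens) for antiproliferative activity, read by CellTiter-Glo, with a stated time of 72 h (on this read-out lower numbers stand for stronger inhibition and higher numbers for weaker inhibition), compound 1 stands at the highest number of the three, meaning it is the weakest inhibitor shown. Compound 2 sits well lower, beyond the scatter, and compound 3 lower still, also beyond the scatter. Both of those carry a larger group on the sulfonyl sulfur than compound 1 does.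

Compound 4, `CC1CCN(C2CCN(S(=O)(=O)c3cn(C)cn3)CC2)CC1`, has not yet been tested. Compared with compound 1 it shows this single change: 1-methyl-1H-imidazol-4-yl in place of pyridin-3-yl on a sulfonyl sulfur. The group that enters is of the same size as the one that leaves, so compound 4 stays close to compound 1 in shape rather than moving toward the larger groups of compounds 2 and 3. No comparison between two measured compounds covers a change of this kind, so the expectation rests only on the weak reading of compound 1 and the similar size of the new group.

For compound 4 the expected step of a 1.2-fold higher number from compound 1 to compound 4 (0.07 log units; within the scatter) is small, not beyond the scatter in either direction. Compound 4 is therefore estimated at 2800 nM, with a likely range from 1100 nM to 7000 nM.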

Compound 4, half-maximal inhibitory concentration: > 5000 nM
Compound 4: no number, only a limit; the forecaster's own chance of this, stated with the estimate: 10%; middle value at least 1.7-fold (0.25 log units) away from the limit.
By their numbers in this assay, from the lowest: compounds 3 and 2 (each within the scatter of the next); then compound 1. At a limit, above all of these: compound 4.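

Compound 4 in this assay gives > 5000 nM, which is a limit of the assay and not a number. Even so, 1-methyl-1H-imidazol-4-yl in place of pyridin-3-yl on a sulfonyl sulfur makes an at least 2.0-fold higher number from compound 1 to compound 4 (0.31 log units; beyond the scatter), so this position responds to a swap between two groups that both count 6 heavy atoms, something that the larger groups of compound 2 and compound 3 could not show. The step has a lower bound but no upper end, because of the kind of reading that compound 4 gave: the limit of > 5000 nM in this assay, at which 1 of the 4 values shown sits.

This swap changes several things at once: a six-membered ring becomes a five-membered one, the ring gains a second nitrogen, and a methyl group arrives, so the compounds shown cannot tell which of these goes with the higher number. Also open, on these data alone, is how the reading would respond to a plain phenyl ring on the sulfonyl sulfur, or to an aromatic ring of this small size carrying an amine or a carboxylic acid, and whether any such group could bring the number down towards those of the larger groups.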